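Trading dimethylcarbamoyl for chloro on compound 2

This account rests on a few compounds, and the source may have more. Where it says the series, first, only, none or still open, it means among the compounds named here.

Of the compounds shown here, three with a shared core have been measured so far in a physicochemical assay for lipophilicity, using the shake flask method, at pH 7.4 (on this read-out higher numbers stand for higher lipophilicity and lower numbers for lower lipophilicity), and they spread widely. Compound 1 (`O=C(O)CCNC(=O)c1ccc(C(Oc2ccc(-n3cc(C(F)(F)F)cn3)cc2)C2CC2)cc1`) reads 1.7 and compound 3 (`CCCC(Nc1cc(C)c(-n2cc(C(F)(F)F)cn2)c(C)c1)c1ccc(C(=O)NCCC(=O)O)cc1`) reads 2.2 on this scale. Compound 2 (`CCCC(Oc1ccc(-n2cc(C(=O)N(C)C)cn2)cc1)c1ccc(C(=O)NCCC(=O)O)cc1`) stands lowest of the three at 0.5 and lies beyond the usual scatter from both of the others.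

Compound 4 (`CCCC(Oc1ccc(-n2cc(Cl)cn2)cc1)c1ccc(C(=O)NCCC(=O)O)cc1`) has not been measured yet. It differs from compound 2 in one place only: chloro in place of dimethylcarbamoyl on an aromatic carbon and the rest of the structure is shared.

Among the compounds with values here, no two measured compounds differ in just one place, so there is no direct step to borrow and any forecast stays rough. The nearest clue is compound 1, which carries trifluoromethyl instead of dimethylcarbamoyl and also differs elsewhere, and it reads 1.7 against the lower number of compound 2. This gap suggests that losing dimethylcarbamoyl may go with a clearly higher number. The estimated change is a number 1.20 log units higher from compound 2 to compound 4 (beyond the scatter) in this assay and it is expected to be upward and beyond the scatter. For compound 4 the expected value is 1.7 with 1.2 to 2.2 as the estimated range.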

Compound 4, distribution coefficient: 2.6
Compound 4: middle estimate off by 0.90 log units, on the low side; the measured number lies above the stated range.
By their numbers in this assay, from the lowest: compound 2; then compound 1; then compound 3; then compound 4.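

Within the data shown here, on the shared core, trading dimethylcarbamoyl for chloro on an aromatic carbon of the five-membered aromatic ring with 2 nitrogen gives a number 2.10 log units higher from compound 2 to compound 4 (beyond the scatter) in this assay, the first step here in which only one place changes. It shows that the reading is highly sensitive to what sits at this position: a group of 5 heavy atoms with 1 hydrogen-bond acceptor leaves, and a single chlorine atom with no hydrogen-bond acceptor enters, while the rest of the structure stays the same. Nothing here establishes why the step is so large, and the features that change together cannot be separated from this one pair.

The compounds shown leave open how a nitrile, a methoxy group or a primary amide at this same place would read, and so whether the number follows the size of the group, its hydrogen-bond acceptor or something else. They also leave open whether the same trade would give a step of similar size on the core of compound 1 or compound 3.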